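A few compounds are considered here, and "the series" means these few. Any claim that something is new, unique, unknown or untested is made for them only; others in the source may bear on it.

Series notes. Compound 1 `O=S(=O)(Nc1ccc2oc(-c3ccccc3)nc2c1)c1ccc(Cl)c(Cl)c1` carries a 3,4-dichlorophenyl on the sulfonyl sulfur. In an assay on cells for inhibition of HSP60/HSP10 (Homo sapiens), with a stated time of 60 min (on this read-out lower numbers stand for stronger inhibition and higher numbers for weaker inhibition), compound 1 gives only a limit, > 100000 nM. Compound 2 `O=S(=O)(Nc1ccc2oc(-c3ccccc3)nc2c1)c1ccccc1Cl` differs by 2-chlorophenyl in place of 3,4-dichlorophenyl on a sulfonyl sulfur; in this assay compound 2 likewise gives only a limit, > 100000 nM. Compound 3 `Cc1cccc(S(=O)(=O)Nc2ccc3oc(-c4ccccc4)nc3c2)c1` has 3-methylphenyl in place of 3,4-dichlorophenyl on a sulfonyl sulfur, and in this assay compound 3 also returns only a limit, > 100000 nM. The measured steps are therefore a step that the two limits leave unreadable from compound 1 to compound 2, a step that the two limits leave unreadable from compound 1 to compound 3 and a step that the two limits leave unreadable from compound 2 to compound 3; the whole of the evidence is the limit of > 100000 nM in this assay, at which 3 of the 3 values shown sit.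

Compound 4 `O=[N+]([O-])c1cc(S(=O)(=O)Nc2ccc3oc(-c4ccccc4)nc3c2)ccc1Cl` is the next variation on the sulfonyl aryl group: nitro in place of chloro on an aromatic carbon. The change sits ortho to a chloro group and meta to a large group. The three measured steps bear on it only insofar as every change of the sulfonyl aryl ring so far has left the read-out at the limit; none gives a readable size, so no direction can be taken from them. The expectation for compound 4 is accordingly that it too sits at or near the limit, estimated at 100000 nM with a range from 30000 nM to 300000 nM. The step this estimate implies is a number no higher from compound 1 to compound 4 (the limit leaves the size open), expected to be none beyond the scatter.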

Compound 4, half-maximal inhibitory concentration: 17000 nM
The estimate for compound 4 lay 5.9-fold (0.77 log units) above the measured number, outside the stated range (below it).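

In this assay, among the compounds shown here, nitro in place of chloro on an aromatic carbon, ortho to a chloro group and meta to a large group, gives an at least 5.8-fold lower number from compound 1 to compound 4 (0.76 log units; beyond the scatter), the only readable step in this set. The steps among the three earlier compounds cannot be read, so they showed no response to any change of the sulfonyl aryl group, whereas this position does respond to the group placed on it. The size of the step stays open at its upper end, since compound 1 supplies only a limit and compound 4 is the only compound here with a number rather than a limit: the limit of > 100000 nM in this assay, at which 3 of the 4 values shown sit.

Whether the lower number is particular to nitro cannot be told from one group at this position; a nitrile, a trifluoromethyl, an amine or a carboxylic acid in the same place would test that. Also open, on these data alone, is whether nitro keeps this effect without the chloro group ortho to it, and whether it would do so on a different sulfonyl aryl group.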